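Amide versus urea on the shared core: cytotoxicity notes

The source may report more compounds than this note shows. Statements on the series, on what has been measured and on what is new or still open speak of the compounds shown alone.

Compound 1 `COc1cc(-c2nn(-c3cccc(NC(=O)c4cccc(C(F)(F)F)c4)c3)cc2-c2ccncc2)ccc1Cl` and compound 2 `COc1cc(-c2nn(-c3cccc(NC(=O)Nc4cccc(C(F)(F)F)c4)c3)cc2-c2ccncc2)ccc1Cl` share a core and differ only on a carbonyl carbon. In a functional assay on NCI-H23 cells (Homo sapiens) for inhibition, read by sulforhodamine B assay, with a stated time of 48 h (a higher number here means that more compound is tolerated, a lower number that less compound is tolerated), compound 1 reaches only the limit > 50000 nM. In this assay compound 2 likewise stands at the limit > 50000 nM, with no number. The step that the two limits leave unreadable from compound 1 to compound 2 is therefore not readable, and the limit of > 50000 nM in this assay, at which 2 of the 2 values shown sit, is the whole of the evidence.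

Compound 3 `COc1cc(-c2nn(-c3cccc(NC(=O)c4ccc(Cl)c(C(F)(F)F)c4)c3)cc2-c2ccncc2)ccc1Cl` is the next member. Its change is 4-chloro-3-(trifluoromethyl)phenyl in place of (3-(trifluoromethyl)phenyl)amino on a carbonyl carbon. It brings back the amide of compound 1 while adding a chloro group on the ring. Going by the values given here, the single measured step bears on it only in being unreadable, so no direction can be taken from it. Compound 3 is expected to stay at the limit as well, with the step that the limit leaves unreadable from compound 2 to compound 3 not readable beyond the limit. The estimate for compound 3 is 60000 nM, within 20000 nM to 200000 nM.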

Compound 3, concentration lethal to 50% of the cells: > 32500 nM
Compound 3: a limit, no number (the forecaster's own chance of this, stated with the estimate: 80%); the middle value is on the limit's open side.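

In this assay compound 3 gives > 32500 nM, which is a limit and not a number. The steps among compound 1, compound 2 and compound 3 therefore cannot be read. The compounds shown leave open whether the amide, the urea or the added chloro changes tolerance on the shared core.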